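This account rests on a few compounds, and the source may have more. Where it says the series, first, only, none or still open, it means among the compounds named here.

In an assay on HEK293 cells for inhibition of transient receptor potential cation channel subfamily V member 1 (Homo sapiens), read by FLIPR (on this read-out lower numbers stand for stronger inhibition and higher numbers for weaker inhibition), compound 2 `Cc1cc(N2CCN(C(=O)Nc3nc4ccc(F)cc4s3)CC2)nnc1Cl` gives only the limit > 10000 nM. Compound 1 `COc1ccc(N2CCN(C(=O)Nc3nc4ccc(F)cc4s3)CC2)nn1` likewise reaches only the limit > 10000 nM in this assay. Hence a step that the two limits leave unreadable from compound 1 to compound 2 cannot be read, and the limit of > 10000 nM in this assay, at which 2 of the 2 values shown sit, is all the measured numbers offer. Compound 3 `Cc1ccnnc1N1CCN(C(=O)Nc2nc3ccc(F)cc3s2)CC1` differs from compound 2 by 4-methylpyridazin-3-yl in place of 6-chloro-5-methylpyridazin-3-yl on an amine nitrogen in a ring. Among the compounds with values here, no measured step speaks to this change, so nothing beyond the scatter can be foreseen, and a result at or near the limit is expected. Compound 3 is estimated at 15000 nM, within a range of 3000 nM to 60000 nM. The implied step that the limit leaves unreadable from compound 2 to compound 3 is expected to be small.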

Compound 3, half-maximal inhibitory concentration: 6170 nM
Beside the measured number, compound 3's estimate is 2.4-fold (0.39 log units) above it, within the range that was stated.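

In this assay, within the data shown here, compound 3, with 4-methylpyridazin-3-yl on the amine nitrogen in the ring, is the only compound here to give a number and not a limit, so a reading at this position is now possible. The change gives an at least 1.6-fold lower number from compound 2 to compound 3 (0.20 log units; that floor lies within the scatter) and an at least 1.6-fold lower number from compound 1 to compound 3 (0.20 log units; that floor lies within the scatter), but both floors lie within the scatter, so no gain can be claimed, and the step between the two limits cannot be read. The values shown still sit mostly at one limit: the limit of > 10000 nM in this assay, at which 2 of the 3 values shown sit.

Left open is how a pyridin-2-yl or a phenyl group in this place would read, and whether any group here would give a step beyond the scatter.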